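The compounds below may be only part of what the source reports. "The series", "measured", "known", "first", "only" and "open" are said of these compounds alone.

Measured so far in a functional assay on A549 cells (Homo sapiens) for cytotoxicity, read by MTT assay, with a stated time of 72 h; a higher number here means a weaker inhibitor, a lower number a stronger inhibitor:
- Compound 1 `Cc1ccc(S(=O)(=O)c2nc3ccccc3nc2N2CCc3ccccc3C2)cc1`: > 50000 nM
- Compound 2 `O=S(=O)(c1ccc(F)cc1)c1nc2ccccc2nc1N1CCc2ccccc2C1`: 22900 nM

Compound 1 gives > 50000 nM, which is a limit of the assay and not a number. This is the limit of > 50000 nM in this assay, at which 1 of the 2 values shown sits.

Compound 3 `Cc1ccc(S(=O)(=O)c2nc3ccccc3nc2N2CCCC(O)C2)cc1` keeps the (4-methylphenyl)sulfonyl group of compound 1 and changes the other substituent: 3-hydroxypiperidin-1-yl in place of 1,2,3,4-tetrahydroisoquinolin-2-yl on an aromatic carbon.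

Among the compounds with values here, the only measured step is an at least 2.1-fold lower number from compound 1 to compound 2 (0.33 log units; beyond the scatter). That step is fluoro in place of methyl on an aromatic carbon, so it does not touch the group exchanged here and gives only a loose guide to size. Within the data shown here, no measured step covers this exchange. A shift of modest size at most is expected in this assay, with no direction favoured, and a further limit is likely.

The expected change is a number no higher from compound 1 to compound 3 (the limit leaves the size open).

For compound 3 the estimate is 50000 nM, with an expected range from 20000 nM to 100000 nM.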

Compound 3, half-maximal inhibitory concentration: 1350 nM
Estimate against measurement, compound 3: 37-fold (1.57 log units) above; the measured number lies below the stated range.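

In this assay, the exchange of 1,2,3,4-tetrahydroisoquinolin-2-yl for 3-hydroxypiperidin-1-yl gives an at least 37-fold lower number from compound 1 to compound 3 (1.56 log units; beyond the scatter), so this carbon of the shared core responds strongly to a change of group, which an at least 2.1-fold lower number from compound 1 to compound 2 (0.33 log units; beyond the scatter) on the other side of the molecule could not show. Going by these compounds, compound 1 gives > 50000 nM, a limit of the assay and not a number, so the true size of the step stays open: the limit of > 50000 nM in this assay, at which 1 of the 3 values shown sits. The entering group lacks the six-membered aromatic ring and carries a hydroxy oxygen, and this single step does not separate those two differences.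

Plain piperidin-1-yl, morpholin-4-yl or 3-aminopiperidin-1-yl at this carbon would bear on which difference counts. Also open, on these data alone, is whether fluoro in place of methyl gives a similar step with 3-hydroxypiperidin-1-yl present.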